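Swapping the benzyl group for a dichlorinated one

A few compounds are considered here, and "the series" means these few. Any claim that something is new, unique, unknown or untested is made for them only; others in the source may bear on it.

Of the compounds shown here, two have been tested in an ADME assay on HEK-293T cells (Homo sapiens) for antiproliferative activity, read by MTT assay, with a stated time of 48 h, in the presence of a further agent that is not named here; on this read-out higher numbers stand for lower toxicity in this test and lower numbers for higher toxicity in this test. Compound 1 `COc1ccc(-c2nn(-c3ccccc3)cc2C(=O)NOCc2ccc(Cl)cc2Cl)cc1` gives 545000 nM in this assay. Compound 2 `O=C(NOCc1ccccc1)c1cn(-c2ccccc2)nc1-c1ccc(F)cc1` gives 217000 nM in this assay, which is the lower of the two numbers; compound 1 lies a step above it that is beyond the usual scatter of this kind of measurement. Compound 3 `O=C(NOCc1ccc(Cl)cc1Cl)c1cn(-c2ccccc2)nc1-c1ccc(F)cc1` has not yet been measured. It differs from compound 2 in one place: 2,4-dichlorophenyl in place of phenyl on a saturated chain carbon bound to an oxygen. For the measured compounds named here, no pair of measured compounds differs by this change alone, so the size of the step cannot be read from a measured pair. Compound 3 shares its dichlorinated benzyl group with compound 1, whose number stands higher than that of compound 2, so a modest rise in the number is expected, though one that may not exceed the scatter. The step from compound 2 to compound 3 is therefore estimated at a 1.5-fold higher number from compound 2 to compound 3 (0.17 log units; within the scatter) in this assay. Compound 3 is expected to give about 320000 nM in this assay, with a likely range from 130000 nM to 750000 nM.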

Compound 3, half-maximal cytotoxic concentration: 45000 nM
Compound 3: middle estimate off by 7.1-fold (0.85 log units), on the high side; measured number below the stated range.
By their numbers in this assay, from the lowest: compound 3; then compound 2; then compound 1.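

With the rest of compound 2 held fixed, the 2,4-dichlorophenyl group in place of phenyl brings a 4.8-fold lower number from compound 2 to compound 3 (0.68 log units; beyond the scatter) in this assay, so at this position on the saturated chain carbon bound to an oxygen, the change goes with higher toxicity in this test. The dichlorinated benzyl group therefore does not bring a high number on its own: with that group kept, fluoro in place of methoxy on an aromatic carbon gives a 12-fold lower number from compound 1 to compound 3 (1.08 log units; beyond the scatter) in the same test, so the high number of compound 1 belongs to the pair with methoxy and cannot be read as a property of the benzyl change alone. Nothing measured on these compounds accounts for either step.

Whether the benzyl change acts the same way when methoxy takes the place of fluoro stays open, as the compounds shown hold no partner that would isolate it. Also open, as far as these compounds go, is how much of the step comes from each chlorine, and whether a benzyl group carrying a single chlorine, or one carrying a methyl group or an amine, would sit nearer to compound 2 or to compound 3.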